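The source may report more compounds than this note shows. Statements on the series, on what has been measured and on what is new or still open speak of the compounds shown alone.

Measured compounds in a functional assay on CEM-DNR-bulk cells (Homo sapiens), read by MTT assay, with a stated time of 72 h; a lower number here means a stronger inhibitor, a higher number a weaker inhibitor:

compound 1, `Nc1nc2c(c(-c3ccccc3)cn2[C@@H]2O[C@H](CO)[C@@H](O)[C@H]2O)c(=O)[nH]1`: > 20000 nM
compound 2, `CNc1ncnc2c1c(-c1cccs1)cn2[C@@H]1O[C@H](CO)[C@@H](O)[C@H]1O`: > 20000 nM
compound 3, `CSc1ncnc2c1c(-c1ccsc1)cn2[C@@H]1O[C@H](CO)[C@@H](O)[C@H]1O`: > 20000 nM

Compound 1 stands at a limit of this assay rather than at a number: in this assay compound 1 gives > 20000 nM, which is a limit. Compound 2 likewise gives only a limit in this assay, > 20000 nM. Compound 3 also gives only a limit in this assay, > 20000 nM. Among the compounds with values here, all three measured values sit at the same limit, (the limit of > 20000 nM in this assay, at which 3 of the 3 values shown sit), so no ordering among compounds 1, 2 and 3 can be read from these numbers, and no step between measured compounds is available to calibrate the change that follows.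

Compound 4, `Nc1nc2c(c(-c3ccoc3)cn2[C@@H]2O[C@H](CO)[C@@H](O)[C@H]2O)c(=O)[nH]1`, is the next compound to be measured in this assay. It differs from compound 1 in one place: furan-3-yl in place of phenyl on an aromatic carbon.

With every measured compound at the limit, nothing among these data shows this kind of change moving the readout beyond the scatter. Compound 4 is therefore expected to stay at the same limit, giving an estimated 20000 nM in this assay, with a range from 8000 nM to 20000 nM. The expected change a number no higher from compound 1 to compound 4 (the limit leaves the size open) is estimated as none beyond the usual scatter.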

Compound 4, half-maximal inhibitory concentration: 15000 nM
Compound 4: middle estimate off by 1.3-fold (0.12 log units), on the high side, and the stated range covers the measured number.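

In this assay compound 4 gives 15000 nM, the first number rather than a limit among the compounds shown, so this aromatic carbon of the five-membered ring can carry a group that brings the readout inside the measurable range. Furan-3-yl in place of phenyl there gives an at least 1.3-fold lower number from compound 1 to compound 4 (0.12 log units; that floor lies within the scatter); the step starts from a limit, so only its floor is known, and that floor does not by itself show a change beyond the scatter, while the true size may be larger. Compound 4 thus stands alone as a measured number, and the other values offer no scale against which to set it: the limit of > 20000 nM in this assay, at which 3 of the 4 values shown sit.

A single step cannot separate the contribution of the ring oxygen from that of the smaller ring, and compounds 2 and 3 differ from compound 4 in more than one place, so they cannot settle it. On these data alone, how this assay would respond to furan-2-yl, to a pyridine ring or to a phenyl ring bearing an amine at this position remains open.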